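Swapping cyclopropylcarbonyl for (thiophen-2-yl)sulfonyl at the assay limit

A few compounds are considered here, and "the series" means these few. Any claim that something is new, unique, unknown or untested is made for them only; others in the source may bear on it.

Compound 1 `Cn1cc(-c2cnc3ccnc(N)c3c2)cn1` gives 40800 nM
Compound 2 `Cn1cc(-c2cnc3ccc(NC(=O)C4CC4)nc3c2)cn1` gives > 50000 nM (a limit)
Compound 3 `Cc1ccc(S(=O)(=O)Nc2ccc3ncc(-c4cnn(C)c4)cc3n2)cc1` gives > 50000 nM (a limit)

In a functional assay on HeLa cells (Homo sapiens) for antiproliferative activity, read by MTT assay, with a stated time of 48 h (a lower number here means a stronger inhibitor, a higher number a weaker inhibitor), compound 2 reads > 50000 nM and this is a limit, not a number. Compound 2 therefore sits at the limit of > 50000 nM in this assay, at which 2 of the 3 values shown sit, and no finer placing is possible. Compound 4 `Cn1cc(-c2cnc3ccc(NS(=O)(=O)c4cccs4)nc3c2)cn1` carries (thiophen-2-yl)sulfonyl in place of cyclopropylcarbonyl on a nitrogen on an aromatic ring and is still unmeasured. Among the compounds with values here, no two measured compounds differ in one place only, so no direct guide to this step exists. Compound 3, which also carries a sulfonyl group, reads > 50000 nM and that too is a limit, so no step beyond the scatter is expected in this assay for this change. The estimate means a number no higher from compound 2 to compound 4 (the limit leaves the size open) as the expected step. For compound 4 the estimated value is 50000 nM with an expected range from 25000 nM to 100000 nM and a limit as the likeliest report.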

Compound 4, half-maximal inhibitory concentration: 38400 nM
Estimate against measurement, compound 4: 1.3-fold (0.11 log units) above, within the range that was stated.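

Compound 2 sits at a limit, not a number: the limit of > 50000 nM in this assay, at which 2 of the 4 values shown sit.

In this assay, (thiophen-2-yl)sulfonyl in place of cyclopropylcarbonyl gives an at least 1.3-fold lower number from compound 2 to compound 4 (0.11 log units; that floor lies within the scatter), and thiophen-2-yl in place of 4-methylphenyl on a sulfonyl sulfur gives an at least 1.3-fold lower number from compound 3 to compound 4 (0.11 log units; that floor lies within the scatter). Going by these compounds, a sulfonyl group on this nitrogen can therefore give a readable number, but neither floor shows a real gain, and the true size of both steps stays unknown.

On these data alone, whether a carbonyl group ending in an amine or a carboxylic acid, or a sulfonyl group with a longer chain in place of thiophen-2-yl, would move the number beyond the scatter stays open.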